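A few compounds are considered here, and "the series" means these few. Any claim that something is new, unique, unknown or untested is made for them only; others in the source may bear on it.

Measured in an ADME assay on TERT-RPE1 cells (Homo sapiens) for cytotoxicity, read by MTT assay, with a stated time of 72 h; a higher number here means a weaker inhibitor, a lower number a stronger inhibitor
compound 1 `COc1ccc(/C=C2/CN(C)/C(=N/c3ccc(C(C)(C)C)cc3)S2)cc1` gives 23500 nM
compound 2 `C=C1CN(C)/C(=N/c2ccccc2)S1` gives > 100000 nM as a limit of the assay, not a number
compound 3 `COc1ccc(/C=C2/CN(C)/C(=N/c3ccc(OC)cc3)S2)cc1` gives 65900 nM

Of the two values that are true numbers, compound 3 holds the higher, with 65900 nM on record. Compound 4 `COc1ccc(/C=C2/CN(C)/C(=N/c3ccc(F)cc3)S2)cc1` carries fluoro in place of methoxy on an aromatic carbon, para to a large group, and the difference counts as fluoro in place of methoxy on an aromatic carbon for this pair. Within the data shown here, one measured step bears on this, a 2.8-fold higher number from compound 1 to compound 3 (0.45 log units; beyond the scatter) for methoxy in place of tert-butyl on an aromatic carbon, and from that modest step a change of similar or smaller size is expected in this assay with no direction set, so possibly none beyond the scatter. The estimated change is a 1.1-fold lower number from compound 3 to compound 4 (0.06 log units; within the scatter) overall. For compound 4 the estimate is 58000 nM with an expected range from 26000 nM to 100000 nM for this compound.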

Compound 4, half-maximal inhibitory concentration: 42800 nM
For compound 4 the middle estimate is 1.4-fold (0.13 log units) above the measured one, within the range that was stated.
By their numbers in this assay, from the lowest: compounds 1, 4 and 3 (each within the scatter of the next, the first and the last beyond it). At a limit, above all of these: compound 2.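

In this assay the 4-methoxyphenyl to 4-fluorophenyl change registers little: a 1.5-fold lower number from compound 3 to compound 4 (0.19 log units; within the scatter). Replacing tert-butyl with fluoro at this position likewise stays small: a 1.8-fold higher number from compound 1 to compound 4 (0.26 log units; within the scatter), so fluoro cannot be separated from either group, although a 2.8-fold higher number from compound 1 to compound 3 (0.45 log units; beyond the scatter). No measurement given here bears on the reason for the size of these steps.

Open, on these data alone, is whether an amine or a carboxylic acid on this aromatic carbon would give a step beyond the scatter from compound 4. The effect of a longer chain there is also unknown.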